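Compound 3: hydrogen in place of methyl on the ring nitrogen

The compounds below may be only part of what the source reports. "The series", "measured", "known", "first", "only" and "open" are said of these compounds alone.

Measured so far in a functional assay on SMMC-7721 cells (Homo sapiens) for cytotoxicity, read by MTT assay, with a stated time of 24 h (on this read-out lower numbers stand for stronger inhibition and higher numbers for weaker inhibition), of the series:
compound 1 `CN1C/C(=C\c2cccnc2)C(=O)/C(=C/c2ccccc2F)C1` gives 5420 nM
compound 2 `CN1C/C(=C\c2cccnc2)C(=O)/C(=C/c2ccccc2C(F)(F)F)C1` gives 3900 nM

Going by the values given here, compound 2 and compound 1 lie within the scatter of each other, so compound 2 holds no separate rank in this assay so far. The unmeasured compound 3 `O=C1/C(=C/c2cccnc2)CNC/C1=C\c1ccccc1C(F)(F)F` differs from compound 2 by hydrogen in place of methyl on an amine nitrogen in a ring. Among the compounds with values here, the only measured step, a 1.4-fold lower number from compound 1 to compound 2 (0.14 log units; within the scatter), is trifluoromethyl in place of fluoro on an aromatic carbon, so it bears only indirectly on this change. Within the data shown here, no measured pair changes the group on that nitrogen, and the direction stays open. No step beyond the scatter is expected in this assay on this evidence. The estimated step is a 1.1-fold lower number from compound 2 to compound 3 (0.05 log units; within the scatter) as an expectation only. Compound 3 is expected at 3500 nM, with an estimated range of 1300 nM to 9000 nM for this measurement.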

Compound 3, half-maximal inhibitory concentration: 5100 nM
Estimate against measurement, compound 3: 1.5-fold (0.16 log units) below; measured number inside the range.
By their numbers in this assay, from the lowest: compounds 2, 3 and 1 (each within the scatter of the next).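

In this assay, going by these compounds alone, hydrogen in place of methyl on the amine nitrogen in the ring gives a 1.3-fold higher number from compound 2 to compound 3 (0.12 log units; within the scatter) and so provides the first direct reading at this position. The step lies within the scatter, so this pair shows no separation between methyl and hydrogen on that nitrogen, with trifluoromethyl held constant on the aromatic carbon. No available evidence accounts for this result.

The compounds shown carry only methyl or hydrogen on that nitrogen, so it remains open whether a longer chain, a benzyl group or an acetyl group there would give a step beyond the scatter. As far as these compounds go, it also remains open whether the same exchange of methyl for hydrogen would stay within the scatter with fluoro in place of trifluoromethyl.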